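Replacing benzyl with 4-methylphenyl on the thiourea nitrogen

The source may hold more compounds than are shown below. What is called first, only, known or untested is meant among the compounds shown, and "the series" means these compounds.

Measured compounds:
compound 1, `COc1ccccc1NC(=S)N/N=C/c1ccc2ccccc2n1`: > 100000 nM
compound 2, `Cc1cccc(NC(=S)N/N=C/c2ccc3ccccc3n2)c1`: > 100000 nM
compound 3, `S=C(NCc1ccccc1)N/N=C/c1ccc2ccccc2n1`: 62800 nM

In a functional assay on HeLa cells (Homo sapiens) for antiproliferative activity, read by sulforhodamine B assay, with a stated time of 72 h (on this read-out higher numbers stand for weaker inhibition and lower numbers for stronger inhibition), compound 1 reaches only the limit of the assay, > 100000 nM, not a number. Compound 2 likewise sits at a limit, > 100000 nM. Within the data shown here, compound 3 gives the only number in this assay, 62800 nM, so it stands alone on the measured scale while the two aryl compounds give no value at all, as the evidence the limit of > 100000 nM in this assay, at which 2 of the 3 values shown sit, shows.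

Compound 4, `Cc1ccc(NC(=S)N/N=C/c2ccc3ccccc3n2)cc1`, has the same atoms as compound 3 joined differently: 4-methylphenyl in place of benzyl on an amide-type nitrogen. Among the measured compounds shown here, the steps that bear on this change are an at least 1.5-fold lower number from compound 1 to compound 3 (0.20 log units; that floor lies within the scatter) and an at least 1.5-fold lower number from compound 2 to compound 3 (0.20 log units; that floor lies within the scatter); both trade an aryl group for benzyl and both lower the number by at least a floor that lies within the scatter. Compound 4 reverses that trade, so the expectation is a higher number, of a size that cannot be read from two limits. For compound 4 the expected step is a 1.8-fold higher number from compound 3 to compound 4 (0.24 log units; within the scatter). Compound 4 is therefore estimated at 110000 nM, with a range from 40000 nM to 300000 nM, and a fair chance that only a limit is reported.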

Compound 4, half-maximal inhibitory concentration: 86000 nM
Compound 4: middle estimate off by 1.3-fold (0.11 log units), on the high side; measured number inside the range.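

In this assay, exchanging benzyl for 4-methylphenyl on the amide-type nitrogen gives a 1.4-fold higher number from compound 3 to compound 4 (0.14 log units; within the scatter), so among the compounds shown, a measured number is no longer confined to benzyl: an aryl group at this position can give one too. The comparisons with the other two aryl groups are much looser, showing an at least 1.1-fold lower number from compound 2 to compound 4 (0.06 log units; that floor lies within the scatter) and an at least 1.1-fold lower number from compound 1 to compound 4 (0.06 log units; that floor lies within the scatter). Only these floors can be given because the values for compound 1 and compound 2 are limits: the limit of > 100000 nM in this assay, at which 2 of the 4 values shown sit.

Going by these compounds, whether moving the methyl group from the 3-methylphenyl arrangement to the 4-methylphenyl arrangement truly changes the number stays open, as that floor lies within the scatter. On these data alone, what a longer chain in place of benzyl, or an amine or a carboxylic acid in place of the methyl group of 4-methylphenyl, would do in this assay also stays open.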